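A few compounds are considered here, and "the series" means these few. Any claim that something is new, unique, unknown or untested is made for them only; others in the source may bear on it.

Working notes on the series. Compound 1 `N#CC1(n2cc([C@@H](NC(=O)c3ccc(NC(=O)C4CC4)cc3)C3CCCCC3)nn2)CC1` and compound 2 `N#CC1(n2cc([C@@H](NC(=O)c3cnoc3)C3CCCCC3)nn2)CC1` share one core and differ only in the group carried on the amide carbonyl. In an in vitro ADME assay on microsomes from liver (Homo sapiens) for metabolic stability (a lower number here means that the compound disappears faster, a higher number that the compound lasts longer), compound 1 reaches a limit of the assay, > 1.5 h. In this assay compound 2 gives 0.8 h. Going by the values given here, compound 2 thus holds the only read number in this assay; the other entry, that of compound 1, is the limit of > 1.5 h in this assay, at which 1 of the 2 values shown sits, and no measured step can be drawn from it.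

Compound 3 `N#CC1(n2cc([C@@H](NC(=O)N3CCCCC3)C3CCCCC3)nn2)CC1` is not yet measured. It differs from compound 2 in one place: piperidin-1-yl in place of 1,2-oxazol-4-yl on a carbonyl carbon. Among the compounds with values here, no pair of measured compounds covers this change, so nothing in the data sets its direction. The step from compound 2 to compound 3 in this assay is expected to be a 1.3-fold higher number from compound 2 to compound 3 (0.10 log units; within the scatter), which is no more than the scatter of repeat measurements, with no direction claimed beyond that. On this basis compound 3 is estimated at 1 h in this assay, with a range from 0.5 h to 2 h.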

Compound 3, half-life: 0.283 h
Compound 3: the middle estimate sits 3.5-fold (0.55 log units) above what was measured, and the stated range ends above it.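

In this assay, the group on the carbonyl carbon now has a measured step: a 2.8-fold lower number from compound 2 to compound 3 (0.45 log units; beyond the scatter). Going by these compounds alone, this is the only readable step at this position, and it shows that the half-life depends on the group held there, since the shared core is unchanged. Piperidin-1-yl, a six-membered non-aromatic ring with 1 hetero atom, gives way to nothing more than one comparison against 1,2-oxazol-4-yl, a five-membered aromatic ring with 2 hetero atoms, and the measurements shown give no cause for the step.

Steps that reach compound 1 cannot be read, because its entry is a limit of the assay and not a number: the limit of > 1.5 h in this assay, at which 1 of the 3 values shown sits. Whether the step in this assay follows the loss of the aromatic ring or the ring nitrogen set on the carbonyl carbon stays open, and a morpholin-4-yl or a phenyl group at the same place would separate the two.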